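Compound 1 to compound 3: acetoxy to methylcarbamoyl

The source may report more compounds than this note shows. Statements on the series, on what has been measured and on what is new or still open speak of the compounds shown alone.

Measured in a functional assay on the whole organism (trachea) for inhibition, with Cavia porcellus as the target; on this read-out lower numbers stand for an effect already at smaller amounts and higher numbers for an effect only at larger amounts of compound:
- compound 1 `COc1ccccc1OCC1SCCN1C(=O)COC(C)=O`: 25 mg/kg
- compound 2 `CCOC(=O)CC(=O)N1CC[S+]([O-])C1COc1ccccc1OC`: 28 mg/kg

Compound 1 at 25 mg/kg and compound 2 at 28 mg/kg lie within the usual scatter of each other, so compound 1 holds no separate rank on these numbers. The next compound to be read is compound 3 `CNC(=O)CC(=O)N1CCSC1COc1ccccc1OC`. It keeps the core of compound 1 and carries methylcarbamoyl in place of acetoxy on a saturated chain carbon bound to a carbonyl carbon.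

Within the data shown here, no pair of measured compounds differs in one place only, so the data give no direct measure of this exchange. With so little to go on, no shift beyond the scatter is expected in this assay, with only a slight lean towards a higher number. The expected step is a 1.4-fold higher number from compound 1 to compound 3 (0.15 log units; within the scatter), and it is estimated with wide uncertainty. For compound 3 the estimated value is 35 mg/kg, with an expected range from 12 mg/kg to 100 mg/kg.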

Compound 3, dose for half-maximal effect: 22 mg/kg
Beside the measured number, compound 3's estimate is 1.6-fold (0.20 log units) above it; measured number inside the range.
By their numbers in this assay, from the lowest: compounds 3, 1 and 2 (each within the scatter of the next).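

Among these compounds, the exchange of acetoxy for methylcarbamoyl on a saturated chain carbon bound to a carbonyl carbon provides the first one-place comparison: in this assay, the result is a 1.1-fold lower number from compound 1 to compound 3 (0.06 log units; within the scatter). At this position, with 4 heavy atoms in both groups, going from 0 hydrogen-bond donors and 2 hydrogen-bond acceptors to 1 hydrogen-bond donor and 1 hydrogen-bond acceptor gives a step that stays within the scatter, so the ester link is not required for a value in this range on the core of compound 1. No measurement shown accounts for this outcome.

Going by these compounds, whether this position stays as flat for groups of another kind remains open, as a carboxylic acid, an amine or a longer chain in the same place would test the reading well beyond this one pair. Compound 2 differs from compound 1 and compound 3 in more than one place, so the separate contributions of its ethyl ester and its changed ring sulfur also remain unresolved.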